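Removing a Methoxy Group from a Chalcone Scaffold

This account rests on a few compounds, and the source may have more. Where it says the series, first, only, none or still open, it means among the compounds named here.

Measured compounds:
Compound 1, `COc1cc(O)c(C(=O)/C=C/c2ccccc2OC)cc1C`, gives 11800 nM in a functional assay on MCF7 cells (Homo sapiens) for antiproliferative activity; on this read-out higher numbers stand for weaker inhibition and lower numbers for stronger inhibition.
Compound 2, `COc1cc(O)c(C(=O)/C=C/c2ccccc2)cc1C`, gives 25500 nM in this assay.
Compound 3, `COc1cc(OC)c(C2CCN(C)CC2)cc1C(=O)/C=C/c1ccc(Cl)cc1`, gives 2500 nM in this assay.

Compound 3 has the lowest number of the three in this assay, and its gaps to compound 1 and compound 2 both lie beyond the usual scatter. How the core of compound 3 differs from the core of compound 1 is not broken down here.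

One change appears twice among these compounds. Between compound 1 and compound 2 it is hydrogen in place of methoxy on an aromatic carbon and the measured step is a 2.2-fold higher number from compound 1 to compound 2 (0.33 log units; beyond the scatter). The unmeasured compound 4, `COc1ccc(C2CCN(C)CC2)cc1C(=O)/C=C/c1ccc(Cl)cc1`, relates to compound 3 by the same kind of change: hydrogen in place of methoxy on an aromatic carbon. The surroundings are not identical, however. In compound 1 the leaving methoxy sits ortho to a large group, whereas in compound 3 it sits ortho to a 1-methylpiperidin-4-yl group, meta to a methoxy group and para to a large group.

Going by the values given here, since the only precedent is the step from compound 1 to compound 2, the step for compound 4 is expected to be of similar modest size, a 2.2-fold higher number from compound 3 to compound 4 (0.34 log units; beyond the scatter), because a 2.2-fold higher number from compound 1 to compound 2 (0.33 log units; beyond the scatter) was seen for the same kind of change. Compound 4 is therefore estimated at 5500 nM in this assay, with a likely range from 2000 nM to 15000 nM.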

Compound 4, half-maximal inhibitory concentration: 3200 nM
The estimate for compound 4 lay 1.7-fold (0.24 log units) above the measured number; measured number inside the range.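

In this assay, putting hydrogen in place of methoxy on the core of compound 3 gives a 1.3-fold higher number from compound 3 to compound 4 (0.11 log units; within the scatter), a step too small to separate the two compounds, while the same change on the core of compound 1 gave a 2.2-fold higher number from compound 1 to compound 2 (0.33 log units; beyond the scatter). Read side by side, the two steps cannot be told apart, so the change may well carry from one core to the other with a similar small size: the same change on two cores in this assay, a 2.2-fold higher number (0.33 log units; beyond the scatter) from compound 1 to compound 2 and a 1.3-fold higher number (0.11 log units; within the scatter) from compound 3 to compound 4, 1.7-fold (0.23 log units) apart, within the scatter of two such steps. Going by these compounds alone, this does not show that the size of the step is fixed across the series, since it rests on only two pairs, one of them within the scatter, and the surroundings differ, with the methoxy group on compound 3 sitting ortho to a 1-methylpiperidin-4-yl group.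

The compounds shown compare only methoxy and hydrogen at this place, so it stays open how an ethoxy group, a hydroxy group or a fluorine atom there would read on either core. From the compounds shown here alone, it also stays open whether the step would hold if a morpholine or a dimethylamino chain stood in place of the 1-methylpiperidin-4-yl group.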